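The source may hold more compounds than are shown below. What is called first, only, known or untested is meant among the compounds shown, and "the series" means these compounds.

In a functional assay on PC-3 cells (Homo sapiens) (a lower number here means a stronger inhibitor of growth, a higher number a weaker inhibitor of growth), compound 1 (`O=S(=O)(/C=C/c1ccc(Cl)cc1Cl)Cc1ccc(Nc2ncnc3ccccc23)cc1`) gives 19000 nM while compound 2 (`O=S(=O)(/C=C/c1ccc(Cl)cc1)Cc1ccc(Nc2ncnc3ccc(Br)cc23)cc1`) gives 2000 nM and compound 3 (`O=S(=O)(/C=C/c1ccc(O)cc1)Cc1ccc(Nc2ncnc3ccc(Br)cc23)cc1`) gives 42000 nM as the highest number of the three, beyond the scatter from both others. Compound 4 (`O=S(=O)(/C=C/c1ccc(Cl)cc1Cl)Cc1ccc(Nc2ncnc3ccc(Br)cc23)cc1`) carries 2,4-dichlorophenyl in place of 4-hydroxyphenyl on a double-bonded chain carbon bound to a double-bonded chain carbon. The closest measured step is a 21-fold higher number from compound 2 to compound 3 (1.32 log units; beyond the scatter) for hydroxy in place of chloro on an aromatic carbon, which is large and beyond the scatter. Taken in reverse, it points to a large fall in the number in this assay on leaving the hydroxy group behind. Among the compounds with values here, compound 4 differs from compound 2 in its 2,4-dichlorophenyl, and no measured step isolates that change. Compound 1 with the same 2,4-dichlorophenyl on its own core gives 19000 nM as a caution against too low a figure. The expected change is a 14-fold lower number from compound 3 to compound 4 (1.15 log units; beyond the scatter) and so a large step to a lower number. The estimate for compound 4 is 3000 nM (range 900 nM to 10000 nM).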

Compound 4, concentration for 50% growth inhibition: 4000 nM
The estimate for compound 4 lay 1.3-fold (0.12 log units) below the measured number, within the range that was stated.
By their numbers in this assay, from the lowest: compounds 2 and 4 (each within the scatter of the next); then compound 1; then compound 3.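

In this assay the change to 2,4-dichlorophenyl on a double-bonded chain carbon bound to a double-bonded chain carbon gives an 11-fold lower number from compound 3 to compound 4 (1.02 log units; beyond the scatter) and so shows that the high number of compound 3 does not carry over to this chlorinated ring. Chloro in place of hydrogen on an aromatic carbon gives a 2.0-fold higher number from compound 2 to compound 4 (0.30 log units; within the scatter) and so leaves compound 2 and compound 4 unseparated in this assay. Bromo in place of hydrogen on an aromatic carbon, with the 2,4-dichlorophenyl kept, gives a 4.8-fold lower number from compound 1 to compound 4 (0.68 log units; beyond the scatter) as a modest step on its own.

From the compounds shown here alone, whether an amine, a methoxy group or a carboxylic acid in place of the chloro would track with hydroxy or with chloro stays open. Nothing measured here accounts for the size of any of these steps.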